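Thiophene Ester in Place of a Sulfonamide on Cyclohexyl

A few compounds are considered here, and "the series" means these few. Any claim that something is new, unique, unknown or untested is made for them only; others in the source may bear on it.

Compound 1 `CS(=O)(=O)NC1CCC(CN2CCN(c3cc(=O)c4cc(C(F)(F)F)cc([N+](=O)[O-])c4s3)CC2)CC1` gives in an ADME assay on cells (Hepatocyte, Homo sapiens) for metabolic stability (a lower number here means that the compound disappears faster, a higher number that the compound lasts longer), a value of > 1.55 h, which is a limit of the assay rather than a number.
Compound 2 `O=c1cc(N2CCN(CC3CCC(NS(=O)(=O)c4ccccc4)CC3)CC2)sc2c([N+](=O)[O-])cc(C(F)(F)F)cc12` gives in this assay a value of > 1.55 h, again a limit of the assay and not a number.

Going by the values given here, compound 2 thus stands only at a limit in this assay, and the one further value shown, that of compound 1, is a limit as well, so that the limit of > 1.55 h in this assay, at which 2 of the 2 values shown sit, is all the assay tells of either. Among the compounds with values here, the step that the two limits leave unreadable from compound 1 to compound 2 is not readable between two limits, and it is the only measured step at hand. Compound 3 `O=C(OC1CCC(CN2CCN(c3cc(=O)c4cc(C(F)(F)F)cc([N+](=O)[O-])c4s3)CC2)CC1)c1cccs1` differs from compound 2 in one place: ((thiophen-2-yl)carbonyl)oxy in place of (phenylsulfonyl)amino on a saturated ring carbon. The measured step bears on this change only in that both of its ends sit at a limit; it cannot set a size or a direction for the step in this assay, nor rule one out beyond the scatter. On these numbers alone compound 3 is expected to fall near the limit, with an estimate of 1.2 h spanning 0.4 h to 3 h. That estimate means an expected step of an at least 1.2-fold lower number from compound 2 to compound 3 (0.11 log units; that floor lies within the scatter).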

Compound 3, half-life: 0.0917 h
Estimate against measurement, compound 3: 13-fold (1.12 log units) above; measured number outside the range, below it.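

In this assay the saturated ring carbon proves sensitive to what it carries: the earlier pair, with both ends at a limit, could show no change there, whereas ((thiophen-2-yl)carbonyl)oxy in place of (phenylsulfonyl)amino shows an at least 16-fold lower number from compound 2 to compound 3 (1.22 log units; beyond the scatter). The same group in place of methanesulfonamido shows an at least 16-fold lower number from compound 1 to compound 3 (1.22 log units; beyond the scatter), so the loss of half-life appears against both sulfonamides shown, and neither of them goes against it. Both sizes are floors and not full sizes, since the sulfonamide end of each step is a limit of the assay and not a number: the limit of > 1.55 h in this assay, at which 2 of the 3 values shown sit.

The change swaps the ring, the linking atom and the sulfonyl for a carbonyl all at once, so the compounds shown do not tell which of these parts carries the step, and an amide such as ((thiophen-2-yl)carbonyl)amino or an ester with a phenyl ring such as (benzoyl)oxy would separate them. On these data alone, the step between the two sulfonamides still cannot be read, and how far either one lasts beyond its limit stays open.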